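From Ethoxy to Methylamino on the Carbonyl of Compound 3

A few compounds are considered here, and "the series" means these few. Any claim that something is new, unique, unknown or untested is made for them only; others in the source may bear on it.

Of the compounds shown here, three have so far been measured in an assay on CHO cells for displacement of a labelled ligand from adenosine receptor A3 (Homo sapiens); on this read-out higher numbers stand for weaker inhibition and lower numbers for stronger inhibition. Compound 1 `CCCNc1nc(C#Cc2ccc(F)s2)nc2c1ncn2[C@H]1[C@H](O)[C@H](O)[C@]2(C(=O)NC)C[C@H]12` gives 1.13 nM, compound 2 `CNC(=O)[C@H]1O[C@@H](n2cnc3c(NC)cc(C#Cc4ccc(F)s4)nc32)[C@H](O)[C@@H]1O` gives 26.6 nM, and compound 3 `CCOC(=O)[C@@]12C[C@@H]1[C@@H](n1cnc3c(NC)nc(C#Cc4ccc(F)s4)nc31)[C@H](O)[C@@H]2O` gives 10.4 nM. On these three numbers compound 3 stands second highest: its nearest neighbour is compound 2, whose number lies higher by a margin beyond the usual scatter, and the furthest is compound 1, whose number lies lower by a wider margin, also beyond the scatter.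

Compound 4 `CNC(=O)[C@@]12C[C@@H]1[C@@H](n1cnc3c(NC)nc(C#Cc4ccc(F)s4)nc31)[C@H](O)[C@@H]2O` has not yet been measured. It differs from compound 3 in one place: methylamino in place of ethoxy on a carbonyl carbon. Among the measured compounds shown here, no pair of measured compounds shows this exact change on a shared core, so its size cannot be read off directly. Compound 1, which carries the methylcarbamoyl group on a closely related core, gives 1.13 nM, the lowest number seen here, so a downward step beyond the scatter is expected. Compound 4 is therefore estimated at 3 nM, with a range from 0.8 nM to 12 nM. The expected step from compound 3 to compound 4 in this assay is a 3.5-fold lower number from compound 3 to compound 4 (0.54 log units; beyond the scatter).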

Compound 4, inhibition constant: 0.28 nM
Beside the measured number, compound 4's estimate is 11-fold (1.03 log units) above it; measured number below the stated range.
By their numbers in this assay, from the lowest: compound 4; then compound 1; then compound 3; then compound 2.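

In this assay the exchange of ethoxy for methylamino on a carbonyl carbon bound to a saturated ring carbon gives a 37-fold lower number from compound 3 to compound 4 (1.57 log units; beyond the scatter) and is a large step, so the number at this position depends strongly on which of the two groups is present. With the methylcarbamoyl group kept in place, hydrogen in place of ethyl on a saturated chain carbon bound to a nitrogen on an aromatic ring gives a 4.0-fold lower number from compound 1 to compound 4 (0.61 log units; beyond the scatter) as a further, modest step beyond the scatter. Nothing at hand accounts for the size of either step.

The compounds shown leave open whether dimethylamino or ethylamino on this carbonyl carbon would stand nearer compound 4 or compound 3. They also leave open how a carboxylic acid at the same place would read.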